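The compounds below may be only part of what the source reports. "The series", "measured", "known", "first", "only" and "open" are said of these compounds alone.

All three measured compounds share one core and carry an isopropyl group on it; they were tested in a functional assay on HepG2 cells (Homo sapiens) for inhibition, read by MTT assay, with a stated time of 72 h; on this read-out higher numbers stand for weaker inhibition and lower numbers for stronger inhibition. Compound 1 `CC(C)n1ncc2c(C(=O)Nc3cccnc3)cccc21` bears a pyridin-3-yl on the amide-type nitrogen, and in this assay compound 1 gives only a limit, > 40000 nM. Compound 2 `CC(C)n1ncc2c(C(=O)NC3CCCC3)cccc21` carries cyclopentyl in place of pyridin-3-yl on that nitrogen, and compound 2 also gives only a limit, > 40000 nM. The step that the two limits leave unreadable from compound 1 to compound 2 is therefore not readable. Compound 3 `Cc1ccc(-n2cc(CNC(=O)c3cccc4c3cnn4C(C)C)nn2)c(C)c1` gives only a limit as well, > 40000 nM. Compound 3 thus stands where every measured value stands: the limit of > 40000 nM in this assay, at which 3 of the 3 values shown sit.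

Compound 4 `Cc1ccc(-n2cc(CNC(=O)c3cccc4c3cnn4C(C)C)nn2)cc1` differs from compound 3 by hydrogen in place of methyl on an aromatic carbon; cut one bond further out, the change reads 2,4-dimethylphenyl to 4-methylphenyl. Within the data shown here, no measured step touches this place, and the only measured step, between compound 1 and compound 2, concerns a different part of the molecule and has no readable size. Among the measured compounds shown here, for compound 4 the step of a number no higher from compound 3 to compound 4 (the limit leaves the size open) is therefore expected to show nothing beyond the scatter, because the limit of > 40000 nM in this assay, at which 3 of the 3 values shown sit, describes every value so far. Compound 4 is estimated at 40000 nM, with a range from 15000 nM to 100000 nM, and most likely only a limit will be reported.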

Compound 4, half-maximal inhibitory concentration: > 40000 nM
Compound 4 was reported as a limit (the forecaster's own chance of this, stated with the estimate: 85%); the middle value lies on the limit itself.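

Among these compounds, compound 3 and compound 4 each give only a limit, so no step between them can be read, and the same holds for every value so far: the limit of > 40000 nM in this assay, at which 4 of the 4 values shown sit. The compounds shown leave open what size of effect any change, to the 2,4-dimethylphenyl group or elsewhere on the shared core, has in this assay.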